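Adding a chloro group to the fluorophenyl of compound 1

The compounds below may be only part of what the source reports. "The series", "measured", "known", "first", "only" and "open" are said of these compounds alone.

Measured compounds:
compound 1 `CCOC(=O)C1=Cc2ccccc2OC1(OCc1cn(-c2ccc(F)cc2)nn1)C(F)(F)F` — 8900 nM
compound 2 `CCOC(=O)C1=Cc2ccccc2OC1(OCc1cc(-c2ccc([N+](=O)[O-])cc2)no1)C(F)(F)F` — > 150000 nM

Among the compounds with values here, in a functional assay on DU-145 cells (Homo sapiens) for inhibition, read by MTT assay, with a stated time of 24 h (a higher number here means a weaker inhibitor, a lower number a stronger inhibitor), compound 1 gives 8900 nM, the only actual number among the two compounds. Compound 2 gives only a limit of the assay, > 150000 nM, and so no number for it is known. Compound 1 therefore stands alone as the one measurable point, with the limit of > 150000 nM in this assay, at which 1 of the 2 values shown sits, being the other entry.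

Compound 3 `CCOC(=O)C1=Cc2ccccc2OC1(OCc1cn(-c2ccc(F)c(Cl)c2)nn1)C(F)(F)F` is not yet measured. It differs from compound 1 in one place: chloro in place of hydrogen on an aromatic carbon. Within the data shown here, no step between two measured compounds is recorded, so no measured precedent for this kind of change exists here.

The step from compound 1 to compound 3 is expected to be small, likely within the usual scatter, perhaps a slight gain in potency: a 1.5-fold lower number from compound 1 to compound 3 (0.17 log units; within the scatter). Compound 3 is therefore estimated at 6000 nM, with a range from 2000 nM to 20000 nM.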

Compound 3, half-maximal inhibitory concentration: 21500 nM
Estimate against measurement, compound 3: 3.6-fold (0.55 log units) below; measured number above the stated range.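

Within the data shown here, this is the first step that can be read in this assay: chloro in place of hydrogen on the aromatic carbon ortho to a fluoro group gives a 2.4-fold higher number from compound 1 to compound 3 (0.38 log units; beyond the scatter) and so counts as a modest loss of potency. The 4-fluorophenyl of compound 1 is therefore not indifferent to a change at this carbon, at least for this one group. Compound 2 has only a limit and differs from compound 1 in more than one place, and nothing shown here bears on the reason for the step.

Going by these compounds, whether a methyl, a methoxy or an amine on the same carbon would also raise the number remains open. So does whether the loss comes with chloro at this carbon alone or would also appear with chloro elsewhere on the ring.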